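The source may hold more compounds than are shown below. What is called first, only, known or untested is meant among the compounds shown, and "the series" means these compounds.

Measured in a functional assay on HeLa cells (Homo sapiens) for cytotoxicity, read by MTT assay; on this read-out higher numbers stand for weaker inhibition and lower numbers for stronger inhibition:
- compound 1 `CC(C)=CC[C@@H](OC(=O)C1CCCO1)C1=CC(=O)c2c(O)ccc(O)c2C1=O`: 17000 nM
- compound 2 `CC(C)=CC[C@@H](OC(=O)CC(C)(O)c1ccccc1)C1=CC(=O)c2c(O)ccc(O)c2C1=O`: 85700 nM

Of these two, compound 2 has the higher number and so the weaker inhibition. Compound 3 `CC(C)=CC[C@@H](OC(=O)C1CCCOC1)C1=CC(=O)c2c(O)ccc(O)c2C1=O` differs from it by oxan-3-yl in place of 2-hydroxy-2-phenylpropyl on a carbonyl carbon. For the measured compounds named here, one measured step bears on this change, a 5.0-fold higher number from compound 1 to compound 2 (0.70 log units; beyond the scatter), where 2-hydroxy-2-phenylpropyl took the place of oxolan-2-yl, another non-aromatic ring with oxygen. Removing 2-hydroxy-2-phenylpropyl is therefore expected to lower the number by a similar amount in this assay. The expected change is a 4.3-fold lower number from compound 2 to compound 3 (0.63 log units; beyond the scatter). For compound 3 the estimate is 20000 nM, with an expected range of 7000 nM to 50000 nM.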

Compound 3, half-maximal inhibitory concentration: 60500 nM
The estimate for compound 3 lay 3.0-fold (0.48 log units) below the measured number; the whole stated range lies below it.
By their numbers in this assay, from the lowest: compound 1; then compounds 3 and 2 (each within the scatter of the next).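

In this assay the change from 2-hydroxy-2-phenylpropyl to oxan-3-yl gives a 1.4-fold lower number from compound 2 to compound 3 (0.15 log units; within the scatter), so removing the aromatic ring and the hydrogen-bond donor does not by itself return the number to that of compound 1. Oxan-3-yl in place of oxolan-2-yl gives a 3.6-fold higher number from compound 1 to compound 3 (0.55 log units; beyond the scatter), so these two non-aromatic rings with oxygen are not interchangeable at this position. No available evidence explains this gap. Left open is whether oxan-2-yl would fall with compound 1 or compound 3, which would separate ring size from the oxygen's place in the ring. On these data alone, how an amine such as piperidin-4-yl would compare also remains open.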